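Restoring a Chloro Group: From Compound 2 to Compound 3

The source may report more compounds than this note shows. Statements on the series, on what has been measured and on what is new or still open speak of the compounds shown alone.

Going by the values given here, compound 2 `O=C1OC(c2ccc(Cl)cc2)=C/C1=C\c1ccc(Cl)cc1` gives 40% in a functional assay on the whole organism (strain Wistar) for inhibition, with Rattus norvegicus as the target, with stated times of 30 min and 2 h, at a dose of 20 mg/kg by the oral route (on this read-out higher numbers stand for more inhibition at the one dose given (going by the name of the read-out) and lower numbers for less inhibition), the lower of the two numbers measured so far; its nearest neighbour, compound 1 `O=C1OC(c2ccc(Cl)cc2)=C/C1=C\c1ccccc1Cl`, gives 62.7%. Among the compounds with values here, the only measured step, a number 22.7 percentage points lower from compound 1 to compound 2 (beyond the scatter), shows that replacing 2-chlorophenyl with 4-chlorophenyl costs inhibition beyond the scatter. Compound 3 `O=C1OC(c2ccc(Cl)cc2)=C/C1=C\c1ccc(Cl)cc1Cl` keeps the 4-chlorophenyl pattern of compound 2 and adds one more substituent: chloro in place of hydrogen on an aromatic carbon, ortho to a large group and meta to a chloro group. This change rebuilds on the ring of compound 2 the arrangement that distinguished compound 1, so the loss from compound 1 to compound 2 is the step that bears on it. The expected step is therefore a rise in this assay of about a number 18 percentage points higher from compound 2 to compound 3 (beyond the scatter). Compound 3 is estimated at 58%, within a range from 42% to 74%.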

Compound 3, a percentage reported as inhibition, in the whole organism at one dose (the size of the read-out at that dose, not a potency): 53.3%
The estimate for compound 3 lay 4.7 percentage points above the measured number; the measured number falls inside the stated range.
By their numbers in this assay, from the lowest: compound 2; then compounds 3 and 1 (each within the scatter of the next).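

In this assay, chloro in place of hydrogen on the aromatic carbon ortho to a large group gives a number 13.3 percentage points higher from compound 2 to compound 3 (beyond the scatter), so on the ring of compound 2 this position accepts a chloro group with a gain beyond the scatter. The same chloro added at the other place on the ring of compound 1 gives a number 9.4 percentage points lower from compound 1 to compound 3 (within the scatter), so the two compounds carrying chloro ortho to a large group cannot be told apart, and a second chloro group on that ring shows no separate effect here. Nothing measured here bears on the reason for these steps.

The compounds shown leave open whether the gain belongs to chloro itself or would also appear with a methoxy group or an amine on that carbon. They also leave open how the numbers would respond if a carboxylic acid replaced the chloro group on the other aromatic ring.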